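The source may hold more compounds than are shown below. What is called first, only, known or untested is meant among the compounds shown, and "the series" means these compounds.

Two measured compounds share one core and differ only in the group attached to a saturated ring carbon. Compound 1 `Cc1cc(O)c(C2=NN(c3ccc(S(N)(=O)=O)cc3)C(c3ccccc3O)C2)cc1Cl` carries a 2-hydroxyphenyl there, and in a functional assay on the whole organism (strain Wistar) for inhibition, with Rattus norvegicus as the target, read by paw edema, with stated times of 30 min and 3 h, at a dose of 20 mg/kg by the oral route (a higher number here means more inhibition at the dose given (going by the name of the read-out), a lower number less inhibition), compound 1 gives 73.6%. Compound 2 `COc1ccc(C2CC(c3cc(Cl)c(C)cc3O)=NN2c2ccc(S(N)(=O)=O)cc2)cc1OC` carries a 3,4-dimethoxyphenyl instead, and in this assay compound 2 gives 60.5%, the lower of the two numbers; the change was a number 13.1 percentage points lower from compound 1 to compound 2 (beyond the scatter).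

Compound 3 `COc1ccc(C2CC(c3cc(Cl)c(C)cc3O)=NN2c2ccc(S(N)(=O)=O)cc2)c(OC)c1OC` is not yet measured. It differs from compound 2 in one place: methoxy in place of hydrogen on an aromatic carbon. Among the measured compounds shown here, no measured step adds a methoxy to a ring that already carries two, so the only guide is the modest downward step from compound 1 to compound 2 when methoxy groups replaced a hydroxyl. A small further fall, or no change beyond the scatter, is therefore expected, as a number 6.5 percentage points lower from compound 2 to compound 3 (within the scatter). For compound 3 the estimate in this assay is 54%, between 40% and 68%.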

Compound 3, a percentage reported as inhibition, in the whole organism at one dose (the size of the read-out at that dose, not a potency): 68.4%
The estimate for compound 3 lay 14.4 percentage points below the measured number; measured number above the stated range.
By their numbers in this assay, from the lowest: compounds 2, 3 and 1 (each within the scatter of the next, the first and the last beyond it).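

In this assay, adding a third methoxy group to the ring gives a number 7.9 percentage points higher from compound 2 to compound 3 (within the scatter) and so brings no change beyond the scatter at this saturated ring carbon. Replacing the 2-hydroxyphenyl with 2,3,4-trimethoxyphenyl gives a number 5.2 percentage points lower from compound 1 to compound 3 (within the scatter) and thus shows that a hydroxyl on this ring is not needed to stay within the scatter of compound 1, although the step to the 3,4-dimethoxyphenyl of compound 2 was beyond it. Nothing available explains why the two methoxy patterns differ in this way.

The compounds shown leave open how this position would respond to a ring with a single methoxy group, or to one carrying an amine or a carboxylic acid. They also leave open whether a longer chain in place of the methoxy groups would be accepted here.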